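The compounds below may be only part of what the source reports. "The series", "measured", "known", "first", "only" and "open" are said of these compounds alone.

Working notes on the series. Compound 1 `CC(C)[C@H](C[C@H]1OC(=O)NC1=O)c1ccc(-c2ccc3cccc(F)c3c2)[nH]c1=O` has the lowest number among the three measured compounds: in a functional assay on CHO cells for antagonist activity at prostaglandin E2 receptor EP3 subtype (Homo sapiens), read by cAMP accumulation, with a stated time of 30 min (a higher number here means a weaker inhibitor, a lower number a stronger inhibitor), compound 1 gives 15 nM. Compound 2 `CC(C)C1(c2ccc(-c3ccc4ccccc4c3)[nH]c2=O)OC(=O)NC1=O`, with its two ring carbonyls joined to a quaternary carbon, gives in this assay 68 nM, a higher number than compound 1 by a margin that lies beyond the scatter. Compound 3 `CC(C)/C(=C1/OC(=O)NC1=O)c1ccc(-c2ccc3cccc(F)c3c2)[nH]c1=O`, in which the link to the heterocycle is an exocyclic double bond, gives in this assay 1300 nM, far higher than compound 1 and well beyond the scatter.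

Compound 4 `CC(C)[C@H](C[C@@H]1OC(=O)NC1=O)c1ccc(-c2ccc3cccc(F)c3c2)[nH]c1=O` has not yet been measured. Its difference from compound 1 is the two compounds have the same atoms and bonds and differ only in configuration as drawn: 1 of 2 stereo elements differ; a stereocentre at a saturated ring carbon is drawn R in compound 1 and S in compound 4. Within the data shown here, no pair of measured compounds differing only at this ring stereocentre is available, so the size of the step cannot be read from measured data. Both configurations remain saturated at the ring carbon, and the chain stereocentre is unchanged, so the expectation is a modest move rather than the large loss seen with compound 3 at 1300 nM; the direction is expected to be towards a higher number, since compound 1 at 15 nM is already the lowest value seen. The estimated step is a 3.0-fold higher number from compound 1 to compound 4 (0.48 log units; beyond the scatter). Compound 4 is expected to give about 45 nM, in the range 10 nM to 200 nM.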

Compound 4, half-maximal inhibitory concentration: 27 nM
Compound 4: middle estimate off by 1.7-fold (0.22 log units), on the high side, within the range that was stated.
By their numbers in this assay, from the lowest: compounds 1 and 4 (each within the scatter of the next); then compound 2; then compound 3.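

In this assay, the series now has its first step that can be read at a single place, the saturated ring carbon: a 1.8-fold higher number from compound 1 to compound 4 (0.26 log units; within the scatter). Within the scatter, then, drawing this ring carbon R or S does not separate the two compounds, and a usable level of inhibition is retained with either configuration. Compounds 2 and 3 could not show this, as neither forms a single-place pair with another compound in the set, whereas this pair isolates one stereocentre because nothing else separates the two structures: the fact that compounds 1 and 4 differ only in the configuration as drawn.

The compounds shown do not tell whether the chain stereocentre, drawn the same in both members of this pair, can be inverted with as little consequence. They also leave open whether the ring carbon stays this permissive with a carboxylic acid in place of the ring bearing the two carbonyls, or with a longer chain in place of the isopropyl group.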